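This account rests on a few compounds, and the source may have more. Where it says the series, first, only, none or still open, it means among the compounds named here.

The measured compounds are compound 1 `COc1ccc(N(CC(=O)NCCC[Te]c2ccccc2)C(=O)CNC(=O)OC(C)(C)C)cc1` with 5000 nM, compound 2 `O=C(COC(=O)/C=C/c1ccccc1)NCCC[Te]c1ccccc1` with 6000 nM, and compound 3 `COc1ccc(N(CC(=O)NCCC[Se]c2ccccc2)C(=O)c2ccccc2)cc1` with >= 100000 nM.

All three were tested in a functional assay on A-431 cells (Homo sapiens) for cytotoxicity, read by MTT assay, with a stated time of 24 h; a higher number here means a weaker inhibitor, a lower number a stronger inhibitor. Compound 1 gives 5000 nM and compound 2 gives 6000 nM, and these two values lie within the usual scatter of each other, so no order between them is claimed. Compound 3 gives >= 100000 nM, which is a limit of the assay and not a number. Compound 3 therefore stands at the limit of >= 100000 nM in this assay, at which 1 of the 3 values shown sits, and its true value is known only to lie at or beyond that point.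

Compound 4 `COc1ccc(N(CC(=O)NCCC[Se]c2ccccc2)C(=O)CNC(=O)OC(C)(C)C)cc1` has not yet been measured in this assay. It differs from compound 3 in one place: ((tert-butoxycarbonyl)amino)methyl in place of phenyl on a carbonyl carbon. Compound 1 carries the same ((tert-butoxycarbonyl)amino)methyl group on its carbonyl carbon and gives 5000 nM in this assay. No step between measured compounds is shown for this change, so its size can only be estimated. The author expects the step from compound 3 to compound 4 to run downward, toward stronger inhibition, by roughly an at least 3.3-fold lower number from compound 3 to compound 4 (0.52 log units; beyond the scatter), with a fair chance that compound 4 still returns only a limit. Compound 4 is estimated at 30000 nM, within a range from 5000 nM to 150000 nM.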

Compound 4, half-maximal inhibitory concentration: >= 100000 nM
Compound 4 gave a limit, no number; the forecaster's own chance of this, stated with the estimate: 45%; middle value at least 3.3-fold (0.52 log units) from the limit.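

In this assay, the ((tert-butoxycarbonyl)amino)methyl group on the carbonyl carbon does not bring the selenium series off the limit: compound 4 gives >= 100000 nM, which is a limit of the assay and not a number, and the change from phenyl cannot be read, as both ends of that step are limits. With the ((tert-butoxycarbonyl)amino)methyl group held constant, exchanging the tellurium-bearing group for the selenium-bearing one gives an at least 20-fold higher number from compound 1 to compound 4 (1.30 log units; beyond the scatter), so this group alone does not carry the cell effect seen for compound 1. With two different groups on the carbonyl carbon, compound 3 and compound 4 now both sit at the same limit: the limit of >= 100000 nM in this assay, at which 2 of the 4 values shown sit.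

The compounds shown leave open how far compound 3 and compound 4 lie beyond that limit, and whether phenyl on the carbonyl carbon would give a number if the chain carried tellurium. Also open, as far as these compounds go, is whether aminomethyl, in place of ((tert-butoxycarbonyl)amino)methyl, or a sulfur-bearing group, in place of the selenium-bearing one, would change the result in this assay.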